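A few compounds are considered here, and "the series" means these few. Any claim that something is new, unique, unknown or untested is made for them only; others in the source may bear on it.

Compound 1 `COc1ccc2c(=O)c(/C=C/C(=O)Nc3cc(C)ccc3C)coc2c1` is examined in a functional assay (QGY7701 cells, Homo sapiens) for inhibition, read by MTT assay, with a stated time of 48 h; on this read-out lower numbers stand for stronger inhibition and higher numbers for weaker inhibition. In this assay compound 1 gives > 100000 nM, which is a limit of the assay and not a number. Compound 2 `Cc1ccc(CNC(=O)/C=C/c2coc3cc(O)ccc3c2=O)cc1` belongs to the same series, and in this assay compound 2 gives 24900 nM. Compound 1 therefore cannot be placed on a number; it sits at the limit of > 100000 nM in this assay, at which 1 of the 2 values shown sits. Compound 3 `CCOc1ccc(NC(=O)/C=C/c2coc3cc(OC)ccc3c2=O)cc1` has not yet been measured in this assay. It differs from compound 1 in one place (4-ethoxyphenyl in place of 2,5-dimethylphenyl on an amide-type nitrogen), a 4-ethoxyphenyl in place of 2,5-dimethylphenyl on an amide-type nitrogen. Going by the values given here, no measured pair differing in one place is available in this assay, so the size of such a change is not known from the data. Compound 3 is expected to move toward stronger inhibition by a step of an at least 1.6-fold lower number from compound 1 to compound 3 (0.22 log units; that floor lies within the scatter), though this remains uncertain. The estimate for compound 3 is 60000 nM, within a range from 15000 nM to 150000 nM.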

Compound 3, half-maximal inhibitory concentration: > 100000 nM
Compound 3 was reported as a limit; the forecaster's own chance of this, stated with the estimate: 40%; middle value at least 1.6-fold (0.22 log units) from the limit.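

In this assay compound 3 gives > 100000 nM, which is a limit of the assay and not a number. Going by these compounds alone, no step between compound 1 and compound 3 can be read, because both stand at a limit: the limit of > 100000 nM in this assay, at which 2 of the 3 values shown sit. The compounds shown leave open whether 4-ethoxyphenyl in place of 2,5-dimethylphenyl on an amide-type nitrogen changes inhibition at all.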